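Methyl on the ring amide nitrogen of compound 1

The source may hold more compounds than are shown below. What is called first, only, known or untested is meant among the compounds shown, and "the series" means these compounds.

Among the measured compounds shown here, in a functional assay for inhibition, with Homo sapiens as the target (a lower number here means that less compound is needed, a higher number that more compound is needed for the effect), compound 1 `CC(=O)Nc1ccc(C2=NNC(=O)CC2)cc1` gives 1 ug/mL and compound 2 `CCC(=O)Nc1ccc(C2=NNC(=O)CC2)cc1` gives 0.64 ug/mL, so compound 1 stands level with its only measured neighbour, within the scatter. Compound 3 `CC(=O)Nc1ccc(C2=NN(C)C(=O)CC2)cc1` is not yet measured and differs from compound 1 by one change: methyl in place of hydrogen on an amide-type nitrogen in a ring. For the measured compounds named here, the one measured step, a 1.6-fold lower number from compound 1 to compound 2 (0.19 log units; within the scatter), places a methyl on a saturated chain carbon bound to a carbonyl carbon, a different place, so it bears only indirectly. Going by the values given here, no measured compound alters the ring nitrogen, which leaves the direction poorly constrained. A modest move towards a higher number in this assay is expected, and the estimated step is a 2.0-fold higher number from compound 1 to compound 3 (0.30 log units; within the scatter). Compound 3 is expected at 2 ug/mL, with an estimated range of 0.5 ug/mL to 10 ug/mL.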

Compound 3, half-maximal effective concentration: > 46.4 ug/mL
Compound 3: no number, only a limit; the forecaster's own chance of this, stated with the estimate: 15%; middle value at least 23-fold (1.36 log units) away from the limit.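

Methyl in place of hydrogen on the amide-type nitrogen in a ring is the only change shown that moves the result in this assay beyond the scatter, with an at least 46-fold higher number from compound 1 to compound 3 (1.66 log units; beyond the scatter). The result for compound 3 is a limit, not a number: the limit of > 46.4 ug/mL in this assay, at which 1 of the 3 values shown sits.

This position therefore responds to a methyl far more strongly than the saturated chain carbon bound to a carbonyl carbon, where the step is a 1.6-fold lower number from compound 1 to compound 2 (0.19 log units; within the scatter).

The compounds shown do not separate the loss of the amide hydrogen from the arrival of the methyl. From the compounds shown here alone, whether an ethyl group or a longer chain ending in an amine on this nitrogen would behave as methyl does also remains open.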